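Removing the cyclopentyl group from the amino nitrogen

The source may report more compounds than this note shows. Statements on the series, on what has been measured and on what is new or still open speak of the compounds shown alone.

The measured compounds, all carrying the same core, are:
compound 1, `CCCCC#Cc1nc(NCc2cccc(Br)c2)c2ncn([C@H]3[C@H](O)[C@H](O)[C@@H]4C[C@@H]43)c2n1`, which in an assay on RBL-2H3 cells for displacement of a labelled ligand from adenosine receptor A3 (Rattus norvegicus), with a stated time of 60 min (on this read-out lower numbers stand for stronger inhibition and higher numbers for weaker inhibition), gives 59 nM;
compound 2, `CCCCC#Cc1nc(NCc2cccc(Cl)c2)c2ncn([C@H]3[C@H](O)[C@H](O)[C@@H]4C[C@@H]43)c2n1`, which in this assay gives 10.7 nM;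
compound 3, `CCCCC#Cc1nc(NC2CCCC2)c2ncn([C@H]3[C@H](O)[C@H](O)[C@@H]4C[C@@H]43)c2n1`, which in this assay gives 58 nM.

Among these three numbers compound 3 stands second highest. Compound 3 and compound 1 sit together, as a 1.0-fold lower number from compound 1 to compound 3 (0.01 log units; within the scatter) shows, while compound 2 lies apart: a 5.4-fold higher number from compound 2 to compound 3 (0.73 log units; beyond the scatter). The remaining step, a 5.5-fold lower number from compound 1 to compound 2 (0.74 log units; beyond the scatter), concerns only the halogen on the benzyl group.

Compound 4, `CCCCC#Cc1nc(N)c2ncn([C@H]3[C@H](O)[C@H](O)[C@@H]4C[C@@H]43)c2n1`, differs from compound 3 in one place: hydrogen in place of cyclopentyl on a nitrogen on an aromatic ring. The two steps that touch this nitrogen, a 1.0-fold lower number from compound 1 to compound 3 (0.01 log units; within the scatter) and a 5.4-fold higher number from compound 2 to compound 3 (0.73 log units; beyond the scatter), exchange one group for another there; they show that what sits on this nitrogen can move the number by a modest amount, in either direction. Within the data shown here, no measured step removes the group altogether, so the direction of the present change cannot be read from the data, and the uncertainty is correspondingly wide.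

Compound 4 is therefore estimated at 300 nM, within a range of 60 nM to 2000 nM, meaning an expected step of a 5.2-fold higher number from compound 3 to compound 4 (0.71 log units; beyond the scatter).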

Compound 4, inhibition constant: 65 nM
Beside the measured number, compound 4's estimate is 4.6-fold (0.66 log units) above it; the range from low to high includes it.
By their numbers in this assay, from the lowest: compound 2; then compounds 3, 1 and 4 (each within the scatter of the next).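

In this assay, replacing the cyclopentyl group on the nitrogen with hydrogen leaves the number within the scatter (a 1.1-fold higher number from compound 3 to compound 4 (0.05 log units; within the scatter)), and the same holds for replacing the 3-bromobenzyl group (a 1.1-fold higher number from compound 1 to compound 4 (0.04 log units; within the scatter)), so neither group shows a measurable gain over the plain amino compound, and the earlier exchanges between groups could not show this. Only the 3-chlorobenzyl group of compound 2 stands apart from hydrogen at this position (a 6.1-fold higher number from compound 2 to compound 4 (0.78 log units; beyond the scatter)), so among these four compounds a substituent on this nitrogen brings a lower number in just that one case, while compounds 1 and 3 go against any general benefit from substitution there. Nothing available explains why the 3-chlorobenzyl group behaves differently from the other two groups.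

The compounds shown leave open whether a methyl group or a longer alkyl chain on this nitrogen would stay level with compound 4 or come closer to compound 2. They also leave open where an unsubstituted benzyl group would fall, which would show whether the lower number of compound 2 depends on the chloro substituent or is lost with any change to it.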